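Working notes on cytotoxicity for compounds 1 to 3

The source may report more compounds than this note shows. Statements on the series, on what has been measured and on what is new or still open speak of the compounds shown alone.

Compound 1 `Cc1ccc(Oc2cccc(CN3CCC(n4cc(C)c(=O)[nH]c4=O)CC3)c2)cc1` has been run in an ADME assay on MRC5 cells (Homo sapiens) for cytotoxicity, read by fluorescence and resazurin assay, with a stated time of 3 days; on this read-out higher numbers stand for weaker inhibition and lower numbers for stronger inhibition. In this assay compound 1 gives > 64000 nM, which is a limit of the assay and not a number. Compound 2 `Cc1cn(C2CCN(Cc3cccc(Oc4ccncc4)c3)CC2)c(=O)[nH]c1=O` shows "not determined" (no result reported) in this assay. The only firm entry is therefore (the limit of > 64000 nM in this assay, at which 1 of the 2 values shown sits). Compound 3 `Cc1cn(C2CCN(Cc3cccc(Oc4ccc(F)c(F)c4)c3)CC2)c(=O)[nH]c1=O` is not yet measured and differs from compound 1 by 3,4-difluorophenyl in place of 4-methylphenyl on an oxygen on an aromatic ring. Among the compounds with values here, with no step between measured compounds to lean on, the expected step is a number no higher from compound 1 to compound 3 (the limit leaves the size open), none beyond the scatter. Compound 3 is expected to give 64000 nM in this assay, within 30000 nM to 150000 nM, most likely reported again only as a limit.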

Compound 3, half-maximal inhibitory concentration: > 64000 nM
Compound 3 gave a limit, no number; the forecaster's own chance of this, stated with the estimate: 80%; the middle value sits exactly at the limit.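

Compound 1 and compound 3 both stand only as limits of the assay in this assay, so no step can be read between them. The compounds shown leave open at what concentration either one would reach half-maximal inhibition.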